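Aryl ether swap on a shared core: cytotoxicity outlook

The source may hold more compounds than are shown below. What is called first, only, known or untested is meant among the compounds shown, and "the series" means these compounds.

Measured compounds:
compound 1, `COc1cc(C#N)cc(OC)c1Oc1nc(Nc2ccc(C#N)cc2)nc2ccccc12`, 194000 nM
compound 2, `N#Cc1ccc(Nc2nc(Oc3ccc(Cl)cc3)c3ccccc3n2)cc1`, 198000 nM
compound 3, `CCCOc1cc(C#N)cc(OC)c1Oc1nc(Nc2ccc(C#N)cc2)nc2ccccc12`, 5200 nM

In an ADME assay on MT4 cells (Homo sapiens) for cytotoxicity, read by MTT assay, with a stated time of 4 days (on this read-out higher numbers stand for lower toxicity in this test and lower numbers for higher toxicity in this test), compound 2 gives 198000 nM, the highest of the three numbers; its nearest neighbour is compound 1, which differs from it within the scatter, and the furthest is compound 3, which lies far below. The unmeasured compound 4, `Cc1cc(Br)cc(Br)c1Oc1nc(Nc2ccc(C#N)cc2)nc2ccccc12`, differs from compound 2 in one place: 2,4-dibromo-6-methylphenyl in place of 4-chlorophenyl on an oxygen on an aromatic ring.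

Within the data shown here, only one step among the measured compounds has been followed, a 37-fold lower number from compound 1 to compound 3 (1.57 log units; beyond the scatter). It sits on the same oxygen on an aromatic ring but involves a different change, so it bears on compound 4 only loosely, showing that a change at this part of the molecule can move the number a long way. For compound 4 a moderate fall is therefore expected, a 3.3-fold lower number from compound 2 to compound 4 (0.52 log units; beyond the scatter), in this assay. Compound 4 is estimated at 60000 nM, within a range from 10000 nM to 200000 nM.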

Compound 4, half-maximal cytotoxic concentration: 150000 nM
Compound 4: the middle estimate sits 2.5-fold (0.40 log units) below what was measured, within the range that was stated.
By their numbers in this assay, from the lowest: compound 3; then compounds 4, 1 and 2 (each within the scatter of the next).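

In this assay the exchange on the oxygen on an aromatic ring gives a 1.3-fold lower number from compound 2 to compound 4 (0.12 log units; within the scatter) and so shows no real change, although the entering 2,4-dibromo-6-methylphenyl has 9 heavy atoms, including 2 bromine, against 7 in the leaving 4-chlorophenyl. A change at this place therefore need not move the number far, and a 37-fold lower number from compound 1 to compound 3 (1.57 log units; beyond the scatter) remains the only large step shown. No supporting evidence bears on this result.

As far as these compounds go, whether an amine or a carboxylic acid on this aromatic ring would leave the number where it stands, or shift it as the ethyl of compound 3 does, remains open. From the compounds shown here alone, it is also open whether a longer chain would extend the step seen with compound 3 and whether that step would recur on the ring of compound 4.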